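This account rests on a few compounds, and the source may have more. Where it says the series, first, only, none or still open, it means among the compounds named here.

Measured so far:
Compound 1, `OCC#CCSc1cnc2ccccc2c1SCC#CCBr`, gives 43.2 ug/mL in a functional assay on P388 cells (Mus musculus) for cytotoxicity, read by MTT assay, with a stated time of 72 h; a higher number here means a weaker inhibitor, a lower number a stronger inhibitor.
Compound 2, `OCC#CCSc1cnc2ccccc2c1[Se]CC#CCO`, gives 4.1 ug/mL in this assay.
Compound 3, `CSc1c(SCC#CCO)cnc2ccccc12`, gives 32.3 ug/mL in this assay.

Compound 3 sits second highest of the three numbers. Its nearest neighbour is compound 1, with a 1.3-fold lower number from compound 1 to compound 3 (0.13 log units; within the scatter), so these two cannot be told apart. Compound 2 is the outlier, with a 7.9-fold higher number from compound 2 to compound 3 (0.90 log units; beyond the scatter).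

Compound 4, `COc1c(SCC#CCO)cnc2ccccc12`, has not yet been measured. It differs from compound 3 by methoxy in place of methylsulfanyl on an aromatic carbon. Among the measured compounds shown here, two measured steps touch the same aromatic carbon: an 11-fold lower number from compound 1 to compound 2 (1.02 log units; beyond the scatter) and a 7.9-fold higher number from compound 2 to compound 3 (0.90 log units; beyond the scatter), both of which swapped much larger groups and moved the number well beyond the scatter. Here only a single atom within a two-atom group changes, and no measured pair shows an oxygen-for-sulfur exchange anywhere. For the measured compounds named here, with no direct precedent, the expected step in this assay is small, a 1.2-fold higher number from compound 3 to compound 4 (0.07 log units; within the scatter), with no direction that can be trusted beyond the scatter.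

Compound 4 is therefore estimated at 38 ug/mL, with a range from 14 ug/mL to 100 ug/mL.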

Compound 4, concentration for 50% inhibition: 23.2 ug/mL
Beside the measured number, compound 4's estimate is 1.6-fold (0.21 log units) above it; low and high end bracket the measured number.
By their numbers in this assay, from the lowest: compound 2; then compounds 4, 3 and 1 (each within the scatter of the next).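

In this assay, among the compounds shown here, the first oxygen-for-sulfur exchange on this aromatic carbon, methoxy in place of methylsulfanyl, gives a 1.4-fold lower number from compound 3 to compound 4 (0.14 log units; within the scatter), so this swap cannot be told apart from no change. A small group can also match a much larger one here: a 1.9-fold lower number from compound 1 to compound 4 (0.27 log units; within the scatter) shows the methoxy of compound 4 within the scatter of the bromine-ended chain of compound 1, whereas a 5.7-fold higher number from compound 2 to compound 4 (0.75 log units; beyond the scatter) keeps compound 2 clearly apart, with the lowest number and so the strongest inhibition of the four compounds. No measured evidence on why these numbers fall as they do is available.

The compounds shown do not separate the two features that set this position in compound 2 apart from compound 1, the selenium link and the hydroxyl at the chain end, so a sulfur-linked chain ending in hydroxyl would be the telling comparison. They also leave open how an amine or an ethoxy group on this aromatic carbon would read in this assay, and whether the flat response seen with methoxy and methylsulfanyl extends beyond these two small groups.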